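The source may hold more compounds than are shown below. What is called first, only, known or untested is meant among the compounds shown, and "the series" means these compounds.

Of the compounds shown here, two have been measured in an in vitro functional assay on SH-EP1 cells for agonist activity at Neuronal acetylcholine receptor; alpha4/beta2 (Homo sapiens), read by FLIPR and calcium flux; a lower number here means a smaller maximal response, a higher number a larger maximal response. Compound 1, `C1=C(c2cncc(Oc3ccccc3)c2)CC2CNCC1C2`, is the larger of the pair: in this assay compound 1 reaches 30%. Compound 2, `CN1C[C@@H]2C=C(c3cccnc3)C[C@@H](C2)C1`, sits lower, and in this assay compound 2 reaches 17%; the gap between these two numbers is beyond the usual scatter of such measurements. Compound 1 therefore stands at the top of what has been measured so far.

Compound 3, `CC(C)Oc1cncc(C2=CC3CNCC(C2)C3)c1`, has not yet been measured. It differs from compound 1 at a single place: isopropyl in place of phenyl on an oxygen on an aromatic ring. The two compounds share everything else, so whatever difference appears in this assay rests on this one exchange. Among the measured compounds shown here, no pair of measured compounds shows a step of this kind, so there is no directly comparable precedent among the numbers above.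

The replacement removes a ring and leaves a short branched chain in its place. The expected step from compound 1 to compound 3 in this assay is a number 5 percentage points lower from compound 1 to compound 3 (within the scatter), a small move downward that may well fall within the scatter. Compound 3 is therefore estimated to reach 25% in this assay, within a range from 8% to 50%.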

Compound 3, largest response reached (reported as percent of maximum), in percent of the reference or control that the assay uses: 54%
Compound 3: middle estimate off by 29 percentage points, on the low side, outside the stated range (above it).
By their numbers in this assay, from the lowest: compound 2; then compound 1; then compound 3.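

In this assay, putting isopropyl in place of phenyl on an oxygen on an aromatic ring gives a number 24 percentage points higher from compound 1 to compound 3 (beyond the scatter), so an aromatic ring at this position is not needed for a sizeable maximal response. The change swaps a ring of 6 heavy atoms for a short branched group of 3 heavy atoms, and the smaller group without a ring is the one that gives the larger response in this pair, which shows that this position can take a group of quite a different shape. Nothing measured here explains why the response rises, and this single exchange offers no independent information on the reason.

This one pair cannot separate the effect of losing the ring from the effect of having fewer atoms, since both happen together in the same change. A cyclopropyl group on the same oxygen would keep a ring at a similar size, while methyl or a longer chain such as n-butyl would show how the response follows the size of the group.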